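Azetidin-1-yl in Place of Dimethylamino on a Carbonyl

This account rests on a few compounds, and the source may have more. Where it says the series, first, only, none or still open, it means among the compounds named here.

Compound 1: `CCC(=O)N1CCC(NS(=O)(=O)c2ccc(NC(=O)c3ccccc3C)c3ccccc23)CC1` — 2.5 nM
Compound 2: `Cc1ccccc1C(=O)Nc1ccc(S(=O)(=O)NC2CCN(C(=O)N(C)C)CC2)c2ccccc12` — 1.6 nM

For the measured compounds named here, in an assay on L1.2 cells for binding affinity to C-C chemokine receptor type 8 (Homo sapiens) (on this read-out higher numbers stand for weaker inhibition and lower numbers for stronger inhibition), compound 2 holds the lower of the two numbers measured so far, but its only neighbour, compound 1, sits close by: the change a 1.6-fold lower number from compound 1 to compound 2 (0.19 log units; within the scatter) is within the scatter, so the two cannot be ranked against each other. That step exchanged one group for another on the same carbonyl carbon that is now altered again.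

Compound 3 `Cc1ccccc1C(=O)Nc1ccc(S(=O)(=O)NC2CCN(C(=O)N3CCC3)CC2)c2ccccc12` keeps everything else of compound 2 and differs from it by azetidin-1-yl in place of dimethylamino on a carbonyl carbon. Going by the values given here, the one measured step that bears on this place, the one from compound 1 to compound 2, did not move the number beyond the scatter, and no other measured pair touches this part of the molecule. A second exchange of the group on this carbonyl carbon is therefore expected to leave this assay essentially unchanged, with the step of a 1.1-fold higher number from compound 2 to compound 3 (0.05 log units; within the scatter) expected to stay within the scatter.

Compound 3 is estimated at 1.8 nM in this assay, with a range from 0.8 nM to 4 nM.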

Compound 3, inhibition constant: 3.5 nM
For compound 3 the middle estimate is 1.9-fold (0.29 log units) below the measured one; the range from low to high includes it.
By their numbers in this assay, from the lowest: compounds 2, 1 and 3 (each within the scatter of the next, the first and the last beyond it).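

For the compounds shown here, this is the first exchange on this carbonyl carbon to move the number in this assay beyond the scatter: azetidin-1-yl, with its four-membered ring and 4 heavy atoms, replaces dimethylamino, with 3 heavy atoms and no ring, and the result is a 2.2-fold higher number from compound 2 to compound 3 (0.34 log units; beyond the scatter), a modest step. The same group set against ethyl gives a 1.4-fold higher number from compound 1 to compound 3 (0.15 log units; within the scatter), so compound 3 cannot be ranked against compound 1, just as compound 2 could not, and only the two ends of this short series can be told apart. Going by these compounds alone, the position therefore responds to the group placed on it, but only slightly across these three compounds, and nothing available explains the one step that can be read.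

The compounds shown cannot separate the effect of closing a ring from that of adding a carbon, since the two changes arrive together in compound 3. A pyrrolidin-1-yl or a diethylamino group on the same carbonyl carbon would speak to that question, and would show whether the number keeps rising as the group grows.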